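This account rests on a few compounds, and the source may have more. Where it says the series, first, only, none or still open, it means among the compounds named here.

Measured so far:
- compound 1 `Cc1cccc(N2C(=O)CSC2c2cccc(C(=O)NCCCCc3ccccc3)c2)c1`: 84%
- compound 2 `O=C(NCCCCc1ccccc1)c1cccc(C2OCC(=O)N2c2cccc(F)c2)c1`: 29%
- compound 3 `CCOc1ccccc1N1C(=O)C(C)SC1c1cccc(C(=O)NCCCCc2ccccc2)c1`: 82%

In a functional assay on HOS cells (Homo sapiens) for inhibition, read by CCK-8 assay, with a stated time of 72 h, tested at 1 uM (a lower number here means less inhibition, a higher number more inhibition at the concentration tested (going by the name of the read-out)), compound 1 gives 84%, the highest of the three numbers. The nearest is compound 3, which gives 82% in this assay, a gap within the scatter, so the two are not ranked against each other. The furthest is compound 2, which gives 29% in this assay, a gap beyond the scatter.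

Compound 4 `COc1ccc(N2C(=O)CSC2c2cccc(C(=O)NCCCCc3ccccc3)c2)c(OC)c1` is not yet measured. Against compound 1 the change is 2,4-dimethoxyphenyl in place of 3-methylphenyl on an amide-type nitrogen in a ring. Among the compounds with values here, no step between two measured compounds isolates this change, so the expected size rests on the values alone: compound 1 and compound 3, which both carry a substituted phenyl on the ring nitrogen, give values within the scatter of each other, which gives no sign that a substituent there moves the number much.

For compound 4 the estimate is 76%, with a range from 52% to 92%. The expected step is a number 8 percentage points lower from compound 1 to compound 4 (within the scatter), small and most likely within the scatter, leaning slightly downward.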

Compound 4, a percentage reported as inhibition, at one concentration (the size of the read-out at that concentration, not a potency): 82%
Compound 4: middle estimate off by 6 percentage points, on the low side; measured number inside the range.
By their numbers in this assay, from the lowest: compound 2; then compounds 3, 4 and 1 (each within the scatter of the next).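

In this assay, within the data shown here, the first single-place step at this position reads a number 2 percentage points lower from compound 1 to compound 4 (within the scatter) and so does not separate 2,4-dimethoxyphenyl from 3-methylphenyl on the amide-type nitrogen in the ring. For this one pair, the entering group brings more heavy atoms and adds hydrogen-bond acceptors, and the read-out shows no difference beyond the scatter. Nothing measured here accounts for this result.

Still open, as far as these compounds go, is whether a phenyl carrying an amine such as dimethylamino or a carboxylic acid, or a longer alkyl chain in place of the phenyl, would stay within the scatter of compound 1. The compounds shown also include no pair differing only at the ring sulfur, so its contribution cannot be read.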